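The source may hold more compounds than are shown below. What is called first, only, known or untested is meant among the compounds shown, and "the series" means these compounds.

Measured so far:
compound 1, `C#CCN(CCCCOc1ccc2ccc(=O)oc2c1)Cc1ccc(OC)cc1`, 54500 nM
compound 2, `C#CCN(CCCOc1ccc2ccc(=O)oc2c1)Cc1ccc(C)cc1`, 116000 nM

Both numbers come from an ADME assay on isolated protein for inhibition of Amine oxidase [flavin-containing] A (Homo sapiens), read by fluorescence and Amplex Red, with stated times of 15 min and 20 min; on this read-out lower numbers stand for stronger inhibition and higher numbers for weaker inhibition. Compound 2 gives the higher of the two numbers in this assay and compound 1 the lower, and the two values lie beyond the usual scatter of each other; as the two compounds differ in more than one place, nothing more is drawn from that pair.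

Compound 3, `C#CCN(CCCOc1ccc2ccc(=O)oc2c1)Cc1ccc(F)c(F)c1`, has not yet been measured in this assay. It differs from compound 2 in one place: 3,4-difluorophenyl in place of 4-methylphenyl on a saturated chain carbon bound to an amine nitrogen. Among the compounds with values here, no measured pair isolates this kind of change, so no step size can be read from the data. With compound 2 at 116000 nM as the only anchor, the step from compound 2 to compound 3 is expected to be small, in either direction, and not clearly beyond the scatter, a 1.3-fold lower number from compound 2 to compound 3 (0.11 log units; within the scatter).

Compound 3 is accordingly estimated at 90000 nM in this assay, with a range from 30000 nM to 270000 nM.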

Compound 3, half-maximal inhibitory concentration: 49200 nM
Compound 3: middle estimate off by 1.8-fold (0.26 log units), on the high side; the range from low to high includes it.
By their numbers in this assay, from the lowest: compounds 3 and 1 (each within the scatter of the next); then compound 2.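

Within the data shown here, on the group carried by the saturated chain carbon bound to an amine nitrogen, this assay gives the first reading of a single change: 3,4-difluorophenyl in place of 4-methylphenyl gives a 2.4-fold lower number from compound 2 to compound 3 (0.37 log units; beyond the scatter). This shows that the number responds to the aryl group at this position, although the step is modest and compound 3 still stands at 49200 nM. No measurement at hand bears on why the number moves with this change.

As far as these compounds go, the swap exchanges whole groups, so the step cannot be divided between the departure of the methyl group and the arrival of either fluorine, and it remains open how an unsubstituted phenyl, a 4-fluorophenyl or a 3-fluorophenyl group would read here. Among these compounds, compound 1 differs from compound 2 and compound 3 in more than one place, so no steps to it can be read, and it remains open whether the 3,4-difluorophenyl group would give a similar step on a longer chain.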